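Replacing propyl by a methoxy-bearing branch: expected cytotoxicity

This account rests on a few compounds, and the source may have more. Where it says the series, first, only, none or still open, it means among the compounds named here.

Among the measured compounds shown here, compound 1 `CCCCn1cc(C(=O)C(=O)Nc2ccc(OC)nc2)c2ccccc21` is the only compound of the three measured that returns a number. In a functional assay on FaDu cells (Homo sapiens) for cytotoxicity, read by MTT assay, with a stated time of 72 h (a higher number here means that more compound is tolerated, a lower number that less compound is tolerated), compound 1 gives 18 nM. Compound 2 `COc1ccc(NC(=O)C(=O)c2cn(C(C)C)c3ccc(Cl)cc23)cc1` returns only a limit, > 10000 nM. Compound 3 `COCCn1cc(C(=O)C(=O)Nc2ccc(OC)nc2)c2cc(Cl)ccc21` likewise returns only a limit, > 10000 nM. For the measured compounds named here, the limit of > 10000 nM in this assay, at which 2 of the 3 values shown sit, is where both of those values sit, so no step between measured compounds can be drawn from them, and none is recorded here.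

Compound 4 `COc1ccc(NC(=O)C(=O)c2cn(CC(C)(C)OC)c3ccccc23)cn1` differs from compound 1 in one place: 1-methoxy-1-methylethyl in place of propyl on a saturated chain carbon bound to an aromatic nitrogen. The rest of the structure is unchanged.

Going by the values given here, no measured pair isolates this change, so the expected size of the step rests on the value of compound 1 alone. Compound 4 is expected to remain measurable, with a modest loss relative to compound 1 that may or may not exceed the usual scatter; the expected step is a 3.3-fold higher number from compound 1 to compound 4 (0.52 log units; beyond the scatter). For compound 4 the estimated value in this assay is 60 nM, within an expected range from 15 nM to 400 nM.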

Compound 4, concentration lethal to 50% of the cells: > 10000 nM
Compound 4 ended at the assay's limit (the forecaster's own chance of this, stated with the estimate: 15%); middle value at least 160-fold (2.22 log units) away from the limit.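

In this assay, the change on the saturated chain carbon bound to an aromatic nitrogen gives an at least 550-fold higher number from compound 1 to compound 4 (2.74 log units; beyond the scatter), with the rest of the structure unchanged. Among the compounds shown here, this pair is the first to differ in one place, so it is the first reading of this position on its own: the single measured number does not survive 1-methoxy-1-methylethyl in place of propyl, and this place therefore does not accept every group. Compound 4 gives only a limit of the assay and not a number, and it joins the other compounds that sit there: the limit of > 10000 nM in this assay, at which 3 of the 4 values shown sit.

The change brings in branching and a methoxy oxygen together, and the compounds shown do not separate the two. On these data alone, whether a 2,2-dimethylpropyl group, with the branching but no oxygen, or a straight chain ending in an amine would keep a measurable value at this place remains open, as does how far the number of compound 4 lies past the limit.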